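Replacing 4-(dimethylamino)phenyl with 2-hydroxyphenyl

The source may hold more compounds than are shown below. What is called first, only, known or untested is meant among the compounds shown, and "the series" means these compounds.

Compound 1 `COc1ccc(/C=C(/C(=O)c2cc(OC)c(OC)c(OC)c2)c2ccc(OC)cc2OC)cc1` value 90000 nM
Compound 2 `COc1ccc(C=C(C(=O)c2cc(OC)c(OC)c(OC)c2)c2ccccc2O)cc1` value 240000 nM
Compound 3 `COc1ccc(/C=C(/C(=O)c2cc(OC)c(OC)c(OC)c2)c2ccc(N(C)C)cc2)cc1` value 150000 nM

All three values come from a functional assay on K562 cells (Homo sapiens) for antiproliferative activity, read by MTT assay, with a stated time of 5 days; on this read-out lower numbers stand for stronger inhibition and higher numbers for weaker inhibition. Compound 3 at 150000 nM lies within the scatter of both other compounds and cannot be ranked against either. The next structure is compound 4 `COc1ccc(/C=C(/C(=O)c2cc(OC)c(OC)c(OC)c2)c2ccccc2O)cc1`, with the change (2-hydroxyphenyl in place of 4-(dimethylamino)phenyl on a double-bonded chain carbon bound to a carbonyl carbon and a double-bonded chain carbon); this puts 2-hydroxyphenyl in place of 4-(dimethylamino)phenyl on a double-bonded chain carbon bound to a carbonyl carbon and a double-bonded chain carbon.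

Among the compounds with values here, the one measured step at this place is a 1.7-fold higher number from compound 1 to compound 3 (0.22 log units; within the scatter) and gives no sign that a change here moves the value much. More direct evidence comes from compound 2, which carries the same 2-hydroxyphenyl and differs from compound 4 only in having no defined double-bond geometry. The effect of that geometry is not shown by these data. With compound 2 at 240000 nM as the closest guide, no step beyond the scatter is expected in this assay. The expected change is a 1.3-fold higher number from compound 3 to compound 4 (0.12 log units; within the scatter) as estimated here. Compound 4 is estimated at 200000 nM, with an expected range from 90000 nM to 450000 nM as the likely span.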

Compound 4, half-maximal inhibitory concentration: 370000 nM
The estimate for compound 4 lay 1.9-fold (0.27 log units) below the measured number; the measured number falls inside the stated range.
By their numbers in this assay, from the lowest: compounds 1, 3, 2 and 4 (each within the scatter of the next, the first and the last beyond it).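

In this assay, the place on the double-bonded chain carbon now shows that it responds to the aryl group, which the earlier step within the scatter did not show: 2-hydroxyphenyl in place of 4-(dimethylamino)phenyl gives a 2.5-fold higher number from compound 3 to compound 4 (0.39 log units; beyond the scatter), and in place of 2,4-dimethoxyphenyl it gives a 4.1-fold higher number from compound 1 to compound 4 (0.61 log units; beyond the scatter). Drawing the double bond as E shows no change beyond the scatter, with a 1.5-fold higher number from compound 2 to compound 4 (0.19 log units; within the scatter), and the comparison rests on a single difference in drawing: the fact that one of compounds 2 and 4 is drawn with a defined configuration and the other without, at the place where they differ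

Going by these compounds, whether a phenyl carrying a carboxylic acid at this place would give a lower number than compound 1 remains open. The compounds shown also leave open how a double bond drawn as Z would read out with 2-hydroxyphenyl, since compound 2 carries no defined configuration.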